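Aryl variation on the triazole nitrogen of the enone series

This account rests on a few compounds, and the source may have more. Where it says the series, first, only, none or still open, it means among the compounds named here.

The shared core of compound 1 `COc1cc(/C=C/C(C)=O)ccc1OCc1cn(-c2c(F)cccc2F)nn1` is kept throughout; the three measured compounds differ only in the aryl group on the aromatic nitrogen. In a functional assay on HCT-116 cells (Homo sapiens) for antiproliferative activity, read by MTT assay, with a stated time of 48 h (a higher number here means a weaker inhibitor, a lower number a stronger inhibitor), compound 1 gives 37700 nM, the second highest of the three numbers. Compound 2 `COc1cc(/C=C/C(C)=O)ccc1OCc1cn(-c2ccccc2OC)nn1` gives 25700 nM, and the step of a 1.5-fold lower number from compound 1 to compound 2 (0.17 log units; within the scatter) lies within the scatter. Compound 3 `CCOC(=O)c1ccc(-n2cc(COc3ccc(/C=C/C(C)=O)cc3OC)nn2)cc1` gives 78900 nM, the highest number of the set, beyond the scatter from compound 1.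

Compound 4 `COc1cc(/C=C/C(C)=O)ccc1OCc1cn(-c2ccc(C=O)cc2)nn1` carries 4-formylphenyl in place of 2,6-difluorophenyl on an aromatic nitrogen. For the measured compounds named here, only one measured step touches this position, from compound 1 to compound 2, and it stayed within the scatter; compound 3 shows that another aryl at the same place gave a higher number. Replacing the aryl therefore looks like a small-to-moderate move, more likely upward than downward, and compound 4 is expected to lie at 50000 nM, with a range from 22000 nM to 115000 nM. The expected step of a 1.3-fold higher number from compound 1 to compound 4 (0.12 log units; within the scatter) is estimated to sit near the edge of the scatter.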

Compound 4, half-maximal inhibitory concentration: 76200 nM
Estimate against measurement, compound 4: 1.5-fold (0.18 log units) below; the range from low to high includes it.
By their numbers in this assay, from the lowest: compounds 2 and 1 (each within the scatter of the next); then compounds 4 and 3 (each within the scatter of the next).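

In this assay, 4-formylphenyl in place of 2,6-difluorophenyl gives a 2.0-fold higher number from compound 1 to compound 4 (0.31 log units; beyond the scatter) and, in place of 2-methoxyphenyl, gives a 3.0-fold higher number from compound 2 to compound 4 (0.47 log units; beyond the scatter) so this aryl exchange on the aromatic nitrogen moves the number beyond the scatter from both compounds. Hydrogen in place of ethoxy on the carbonyl carbon gives a 1.0-fold lower number from compound 3 to compound 4 (0.02 log units; within the scatter) so that exchange stays within the scatter, and compounds 3 and 4, whose aryl groups both carry a carbonyl, sit together above compounds 1 and 2. Nothing available explains this separation or gives a measured property of these groups.

Still open, as far as these compounds go, is whether an amine or a carboxylic acid in place of the formyl group would stay with compounds 3 and 4 or move towards compounds 1 and 2. Also open, from the compounds shown here alone, is whether the carbonyl itself or the place it occupies on the aryl group accounts for the separation.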